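Trimming the amine side chain of compound 2

This account rests on a few compounds, and the source may have more. Where it says the series, first, only, none or still open, it means among the compounds named here.

Compound 1 `N[C@@H]1CCc2ccccc2N(Cc2ccc(-c3ccccc3-c3nn[nH]n3)cc2)C1=O`: 9 uM
Compound 2 `CC(C)CNC(C)(C)CC(=O)N[C@@H]1CCc2ccccc2N(Cc2ccc(-c3ccccc3-c3nn[nH]n3)cc2)C1=O`: 85 uM

In a functional assay on cells (Pituitary gland cell) with growth hormone secretagogue receptor type 1 (Rattus norvegicus) as the target (on this read-out higher numbers stand for an effect only at larger amounts of compound and lower numbers for an effect already at smaller amounts), compound 1 gives 9 uM, while compound 2 gives 85 uM, the higher of the two numbers. Compound 3 `CCCNC(C)(C)CC(=O)N[C@@H]1CCc2ccccc2N(Cc2ccc(-c3ccccc3-c3nn[nH]n3)cc2)C1=O` differs from compound 2 by hydrogen in place of methyl on a saturated chain carbon bound to two saturated chain carbons, isobutylamino to propylamino. Going by the values given here, the single measured step, a 9.4-fold higher number from compound 1 to compound 2 (0.98 log units; beyond the scatter), adds the whole carbonyl side chain and bears only loosely on this; no step removes one methyl from that chain. The expected step is therefore small, a 1.2-fold lower number from compound 2 to compound 3 (0.08 log units; within the scatter), within the scatter. Compound 3 is estimated at 70 uM, between 20 uM and 250 uM.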

Compound 3, concentration for half-maximal effect: 50 uM
For compound 3 the middle estimate is 1.4-fold (0.15 log units) above the measured one; the range from low to high includes it.
By their numbers in this assay, from the lowest: compound 1; then compounds 3 and 2 (each within the scatter of the next).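

In this assay, exchanging isobutylamino for propylamino gives a 1.7-fold lower number from compound 2 to compound 3 (0.23 log units; within the scatter), so removing this methyl makes no difference that can be told from the scatter. The propylamino side chain still stands apart from the free amine, with a 5.6-fold higher number from compound 1 to compound 3 (0.74 log units; beyond the scatter), so the higher number that comes with the side chain does not depend on that methyl. Nothing available explains either result. Still open, going by these compounds, is whether a butylamino or ethylamino group at this end of the chain would stand apart from compound 2 by more than the scatter.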